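The source may report more compounds than this note shows. Statements on the series, on what has been measured and on what is new or still open speak of the compounds shown alone.

Compound 1 `COc1ccc2c(=O)c(/C=C/C(=O)Nc3ccc(C)cc3)coc2c1` is one of three related compounds tested in an ADME assay on HepG2 2.2.15 cells (Homo sapiens) for cytotoxicity, read by MTT assay, with stated times of 48 h and 9 days; on this read-out higher numbers stand for lower toxicity in this test and lower numbers for higher toxicity in this test. In this assay compound 1 gives 979000 nM, the highest of the three numbers. Compound 2 `COc1ccc2c(=O)c(/C=C/C(=O)NCc3ccc(F)cc3)coc2c1` gives 133000 nM, and compound 3 `CCOc1ccc(NC(=O)/C=C/c2coc3cc(OC)ccc3c2=O)cc1` gives 460000 nM. Both changes away from compound 1 lower the number: a 7.4-fold lower number from compound 1 to compound 2 (0.87 log units; beyond the scatter) and a 2.1-fold lower number from compound 1 to compound 3 (0.33 log units; beyond the scatter), while a 3.5-fold higher number from compound 2 to compound 3 (0.54 log units; beyond the scatter) runs the other way.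

Compound 4 `COc1ccc2c(=O)c(/C=C/C(=O)Nc3ccccc3Cl)coc2c1` has not yet been tested. It differs from compound 1 in one place: 2-chlorophenyl in place of 4-methylphenyl on an amide-type nitrogen. The two measured steps that change the group on the amide-type nitrogen both moved the number down by a modest amount, so a modest downward step in this assay is the expectation here too, though the exact size is uncertain. The estimated step is a 2.0-fold lower number from compound 1 to compound 4 (0.29 log units; within the scatter). Compound 4 is expected to give about 500000 nM in this assay, most likely somewhere between 150000 nM and 1200000 nM.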

Compound 4, half-maximal cytotoxic concentration: 1010000 nM
Compound 4: middle estimate off by 2.0-fold (0.31 log units), on the low side; low and high end bracket the measured number.
By their numbers in this assay, from the lowest: compound 2; then compound 3; then compounds 1 and 4 (each within the scatter of the next).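

Not every change on the amide-type nitrogen separates compounds in this assay: 2-chlorophenyl in place of 4-methylphenyl gives a 1.0-fold higher number from compound 1 to compound 4 (0.01 log units; within the scatter), whereas the earlier steps at this place all lay beyond the scatter. The new group also sets the other two apart, with a 2.2-fold higher number from compound 3 to compound 4 (0.34 log units; beyond the scatter) and a 7.6-fold higher number from compound 2 to compound 4 (0.88 log units; beyond the scatter), so among these compounds, lower numbers, and so higher toxicity in this test, go with 4-ethoxyphenyl and most of all with 4-fluorobenzyl. No measurement on hand explains these differences.

Still open, as far as these compounds go, is whether the chlorine's place on the ring matters, which a 4-chlorophenyl group on the same nitrogen would test directly. It is also unknown how the number would respond to a ring carrying an amine or a carboxylic acid, or to a longer chain in place of the ring.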